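A few compounds are considered here, and "the series" means these few. Any claim that something is new, unique, unknown or untested is made for them only; others in the source may bear on it.

Measured so far in a functional assay on HL-60 cells (Homo sapiens) for cytotoxicity, read by luminescence and CellTiter-Glo, with a stated time of 3 days (on this read-out higher numbers stand for weaker inhibition and lower numbers for stronger inhibition), are three compounds:
- compound 1 `N#Cc1ccc(NC(=O)c2cc(-c3ccncc3)ccc2O)cc1` gives 5410 nM
- compound 2 `N#Cc1ccc(NC(=O)c2ccc(Br)cc2O)cc1Cl` gives 440 nM
- compound 3 `O=C(Nc1ccc(OC(F)(F)F)c(Cl)c1)c1cc(F)ccc1O` gives 550 nM

Compound 1 has the highest number of the three and is the weakest here, with its gaps to compound 3 and compound 2 both beyond the scatter. Compound 2 and compound 3 lie within the scatter of each other. Within the data shown here, no pair of measured compounds differs in only one place, so the series offers indirect guidance only.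

Next in line is compound 4 `N#Cc1ccc(NC(=O)c2cc(Cl)ccc2O)cc1` with the core of compound 1 kept. The change (chloro in place of pyridin-4-yl on an aromatic carbon) puts chloro in place of pyridin-4-yl on an aromatic carbon, para to a hydroxy group. Neither compound 2 at 440 nM nor compound 3 at 550 nM carries pyridin-4-yl and each holds a halogen, although both also differ from compound 4 elsewhere. On that indirect evidence, a step to a lower number beyond the scatter is expected in this assay with real uncertainty in its size. The estimated step is a 6.8-fold lower number from compound 1 to compound 4 (0.83 log units; beyond the scatter) and would mean stronger inhibition. Compound 4 is expected at 800 nM within an estimated range of 250 nM to 2500 nM as a working figure.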

Compound 4, half-maximal inhibitory concentration: 700 nM
For compound 4 the middle estimate is 1.1-fold (0.06 log units) above the measured one, and the stated range covers the measured number.
By their numbers in this assay, from the lowest: compounds 2, 3 and 4 (each within the scatter of the next); then compound 1.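

Among these compounds, this is the first comparison that isolates one change. In this assay, at the aromatic carbon para to a hydroxy group, chloro in place of pyridin-4-yl gives a 7.7-fold lower number from compound 1 to compound 4 (0.89 log units; beyond the scatter), so the group held at this position clearly affects the read-out with the rest of the core of compound 1 kept. The earlier compounds shown here could not show this, as compound 2 and compound 3 each differ from compound 1 in more than one place. No measurement in hand bears on why the step occurs.

The change swaps a six-membered aromatic ring with 1 hetero atom and 6 heavy atoms for a single chlorine atom, so this one pair cannot separate the loss of the ring from the arrival of the halogen. A plain phenyl ring, a methoxy group, an amine or a carboxylic acid at this position would help to tell those two apart, and would show whether chloro is special here or whether pyridin-4-yl is simply poorly tolerated.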